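This account rests on a few compounds, and the source may have more. Where it says the series, first, only, none or still open, it means among the compounds named here.

Within the data shown here, compound 2 `CCOc1ccccc1Nc1nc2nonc2nc1Nc1ccccc1F` is the only compound here with an actual number: in an assay on mitochondria from L6 cells (Rattus norvegicus) for activation, with a stated time of 90 min (on this read-out higher numbers stand for an effect only at larger amounts of compound and lower numbers for an effect already at smaller amounts), compound 2 gives 5600 nM. Compound 1 `Fc1ccccc1Nc1nc2nonc2nc1NCCC(F)(F)F` differs from it only on a nitrogen on an aromatic ring, where it carries 3,3,3-trifluoropropyl instead of 2-ethoxyphenyl. In this assay compound 1 reaches only a limit of the assay, > 100000 nM. Among the measured compounds shown here, the single measured step, an at least 17-fold lower number from compound 1 to compound 2 (1.25 log units; beyond the scatter), is thus known only as a lower bound, because it starts from the limit of > 100000 nM in this assay, at which 1 of the 2 values shown sits. Compound 3 `Oc1ccc(F)c(Nc2nc3nonc3nc2Nc2ccccc2F)c1` alters the same nitrogen again: 2-fluoro-5-hydroxyphenyl in place of 2-ethoxyphenyl on a nitrogen on an aromatic ring. The measured step swapped a chain for an aromatic ring, whereas this change keeps an aromatic ring and merely rearranges what sits on it, so it says little about the size to expect; a step inside the usual scatter of this assay, in either direction, seems most likely. Compound 3 is expected to give 5000 nM in this assay, between 1500 nM and 20000 nM. That amounts to an estimated step of a 1.1-fold lower number from compound 2 to compound 3 (0.05 log units; within the scatter).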

Compound 3, half-maximal effective concentration: 30000 nM
Beside the measured number, compound 3's estimate is 6.0-fold (0.78 log units) below it; measured number above the stated range.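

In this assay, keeping an aromatic ring on this nitrogen is not enough to hold the number, since what the ring carries also counts: 2-fluoro-5-hydroxyphenyl in place of 2-ethoxyphenyl gives a 5.4-fold higher number from compound 2 to compound 3 (0.73 log units; beyond the scatter). Even so, 2-fluoro-5-hydroxyphenyl still compares favourably with the 3,3,3-trifluoropropyl chain, with an at least 3.3-fold lower number from compound 1 to compound 3 (0.52 log units; beyond the scatter). That second step is only a lower bound, because compound 1 stands at a limit of the assay and not at a number: the limit of > 100000 nM in this assay, at which 1 of the 3 values shown sits.

Compound 3 loses the ethoxy group and gains both a fluorine and a hydroxyl group, and the compounds shown do not separate these changes. Going by these compounds, it also remains open how an unsubstituted phenyl ring, or a phenyl ring carrying an amine or a carboxylic acid, would behave on this nitrogen.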